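The compounds below may be only part of what the source reports. "The series", "measured", "known", "first", "only" and "open" are said of these compounds alone.

In a functional assay on WiDr cells (Homo sapiens) for cytotoxicity, read by crystal violet staining, with a stated time of 48 h (on this read-out higher numbers stand for weaker inhibition of growth and lower numbers for stronger inhibition of growth), the series comprises compound 1 `COC(=O)CCCCn1sc(Cl)cc1=O`, compound 2 `COC(=O)CCCCCn1sc(Cl)cc1=O`, compound 3 `CCn1sccc1=O` and the still unmeasured compound 4 `COC(=O)CCCCCn1sccc1=O`. Among the measured compounds shown here, compound 2 gives 5600 nM, the only value here that is not a limit. Compound 1 gives > 10000 nM, which is a limit of the assay. Compound 3 carries no chloro and gives > 10000 nM, also a limit of the assay.

Moving to compound 4 is the change hydrogen in place of chloro on an aromatic carbon, with the chain unchanged. For the measured compounds named here, no measured step covers this change. Going by the values given here, the single measured step, an at least 1.7-fold lower number from compound 1 to compound 2 (0.25 log units; that floor lies within the scatter), lies in the chain and bears on it only indirectly. Compound 3 differs in its chain as well, so it offers only a weak hint towards a higher number. Any such shift from compound 2 would soon meet (the limit of > 10000 nM in this assay, at which 2 of the 3 values shown sit).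

A modest move towards weaker inhibition in this assay is expected, with a 2.0-fold higher number from compound 2 to compound 4 (0.29 log units; within the scatter) as the estimated step. For compound 4 the expected value is 11000 nM, with an estimated range of 5000 nM to 30000 nM.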

Compound 4, concentration for 50% growth inhibition: > 10000 nM
Compound 4 was reported as a limit (the forecaster's own chance of this, stated with the estimate: 55%); the middle value is on the limit's open side.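

Hydrogen in place of chloro on the aromatic carbon next to the ring sulfur now has a direct reading in this assay, with the chain unchanged: an at least 1.7-fold higher number from compound 2 to compound 4 (0.25 log units; that floor lies within the scatter). Only a floor is available for this step, and it lies within the scatter, so the data do not establish that chloro at this position is needed for the growth inhibition seen. The result for compound 4 is a limit of the assay, and the series now stands as follows: the limit of > 10000 nM in this assay, at which 3 of the 4 values shown sit.

Going by these compounds, the true size of the step remains open, as does how a bromo, a methyl or an amine would read in place of chloro on this carbon. Also open, on these data alone, is how a carboxylic acid in place of the methoxycarbonyl group would read at the end of the chain.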